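This account rests on a few compounds, and the source may have more. Where it says the series, first, only, none or still open, it means among the compounds named here.

Measured so far in a functional assay on HL-60 cells (Homo sapiens) for antiproliferative activity, read by MTT assay, with a stated time of 72 h; on this read-out lower numbers stand for stronger inhibition and higher numbers for weaker inhibition
- compound 1 `CCn1cc(C(=O)O)c(=O)c2cc(F)c(N3CCN(C(=N)NS(=O)(=O)c4cccc(Cl)c4)CC3)cc21` at 43 nM
- compound 2 `CCn1cc(C(=O)O)c(=O)c2cc(F)c(N3CCN(C(=N)NS(=O)(=O)c4ccccc4C(F)(F)F)CC3)cc21` at 43 nM

Going by the values given here, compound 2 stands level with compound 1, with no change at the digits printed from compound 1 to compound 2 (within the scatter) as the only measured step. Next comes compound 3 `CCn1cc(C(=O)O)c(=O)c2cc(F)c(N3CCN(C(=N)NS(=O)(=O)c4ccc(C)cc4)CC3)cc21` with 4-methylphenyl in place of 2-(trifluoromethyl)phenyl on a sulfonyl sulfur. Among the compounds with values here, the same place changed in no change at the digits printed from compound 1 to compound 2 (within the scatter) and that single step is the only evidence, so no shift beyond the scatter is expected in this assay and neither direction is favoured. The estimated step is a 1.0-fold higher number from compound 2 to compound 3 (0.02 log units; within the scatter) and rests on that one comparison. Compound 3 is expected at 45 nM with an estimated range from 18 nM to 110 nM on this thin basis.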

Compound 3, half-maximal inhibitory concentration: 43 nM
Beside the measured number, compound 3's estimate is 1.0-fold (0.02 log units) above it, within the range that was stated.
By their numbers in this assay, from the lowest: compounds 1, 2 and 3 (each within the scatter of the next).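

In this assay, replacing either earlier aryl group with 4-methylphenyl on the sulfonyl sulfur gives no change at the digits printed from compound 2 to compound 3 (within the scatter) and no change at the digits printed from compound 1 to compound 3 (within the scatter). This place now has three substituted phenyl groups at one level, including one that carries only carbon in its substituent, so the flat reading no longer rests on a single pair. No measurement offered here accounts for this flat reading.

Still open, from the compounds shown here alone, is whether a non-aromatic group, such as a straight alkyl chain, would hold this level. A phenyl ring bearing an amine or a carboxylic acid is equally untested among the compounds shown.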